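A few compounds are considered here, and "the series" means these few. Any claim that something is new, unique, unknown or untested is made for them only; others in the source may bear on it.

Compound 3 `COC(=O)/C=C/c1cccc(NC(=O)C2CCCCC2)c1` is the smallest member of this set: its amide nitrogen still carries a plain hydrogen. In an assay on isolated protein with Bile acid receptor (Homo sapiens) as the target (a lower number here means that less compound is needed, a higher number that more compound is needed for the effect), compound 3 reaches only a limit of the assay, > 1000 nM, so no number is known for it. Two larger relatives carry a bulky group on that nitrogen instead: compound 1 `COC(=O)/C=C/c1cccc(N(Cc2ccc(/C=C/c3c(C)cc(C)cc3C)cc2)C(=O)C(C)C)c1` gives 149 nM in this assay, and compound 2 `COC(=O)/C=C/c1cccc(N(Cc2ccc(-c3ccc(F)c(Cl)c3)cc2)C(=O)C2CCCCC2)c1` gives 66 nM. Compound 4 `COC(=O)/C=C/c1cccc(N(C(=O)C2CCCCC2)c2ccc3ccccc3c2)c1` follows the same idea: naphthalen-2-yl in place of hydrogen on an amide-type nitrogen. Compound 1 with 149 nM and compound 2 with 66 nM show that a large group on that nitrogen goes together with a measurable value. Accordingly a step toward lower values is expected from compound 3 to compound 4, an at least 2.5-fold lower number from compound 3 to compound 4 (0.39 log units; beyond the scatter). Compound 4 is expected to give about 400 nM in this assay, within a range from 100 nM to 2000 nM.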

Compound 4, half-maximal effective concentration: 680 nM
Compound 4: the middle estimate sits 1.7-fold (0.23 log units) below what was measured; measured number inside the range.
By their numbers in this assay, from the lowest: compound 2; then compound 1; then compound 4. At a limit, above all of these: compound 3.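

With naphthalen-2-yl sitting directly on the amide-type nitrogen, compound 4 gives 680 nM in this assay, so this position can carry two aromatic rings without any linking carbon and still yield a number. The change amounts to an at least 1.4-fold lower number from compound 3 to compound 4 (0.16 log units; that floor lies within the scatter), so this pair alone does not establish a real gain. Compound 3 stands at a limit rather than a number, and the true step remains unknown because of this: the limit of > 1000 nM in this assay, at which 1 of the 4 values shown sits.

On these data alone, whether a smaller group on that nitrogen, such as methyl or phenyl, also gives a number stays open.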